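The source may report more compounds than this note shows. Statements on the series, on what has been measured and on what is new or still open speak of the compounds shown alone.

In an ADME assay on J774 cells (Mus musculus) for cytotoxicity (on this read-out lower numbers stand for an effect already at smaller amounts and higher numbers for an effect only at larger amounts of compound), compound 1 (`CCCCc1cc2c(=O)c(C(C)=O)c[nH]c2cc1OCCOc1ccccc1`) gives "not determined" (no result reported) as its entry, so it offers no number to start from. Going by the values given here, the only nearby guide is the smaller compound 2 (`CCc1ccc2[nH]cc(C(=O)OC)c(=O)c2c1`). Compound 2 gives > 20000 nM here, and this is a limit of the assay, not a number. Compound 3 (`CCCCc1cc2c(=O)c(C(=O)NCCO)c[nH]c2cc1OCCOc1ccccc1`) differs at one place ((2-hydroxyethyl)amino in place of methyl on a carbonyl carbon), with (2-hydroxyethyl)amino in place of methyl on a carbonyl carbon. Among the compounds with values here, no measured step exists for comparison, so no shift beyond the usual scatter is expected in this assay from this change. Compound 3 is estimated at 20000 nM (expected range 6000 nM to 60000 nM) in this test.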

Compound 3, half-maximal effective concentration: > 20000 nM
Compound 3: a limit, no number; the forecaster's own chance of this, stated with the estimate: 60%; the middle value lies on the limit itself.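

Compound 1 has no reported result and compound 3 gives only a limit, not a number, and no step can be read between them. The compounds shown leave open what the change from acetyl to (2-hydroxyethyl)carbamoyl does in this assay.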